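A few compounds are considered here, and "the series" means these few. Any claim that something is new, unique, unknown or untested is made for them only; others in the source may bear on it.

Measured in an ADME assay on MT4 cells (Homo sapiens) for cytotoxicity, read by MTT assay, with a stated time of 5 days; on this read-out higher numbers stand for lower toxicity in this test and lower numbers for higher toxicity in this test:
- compound 1 `C=CCNc1cc(Oc2c(C)cc(/C=C/C#N)cc2C)cc(Nc2ccc(C#N)cc2)n1`: 82100 nM
- compound 2 `Cc1cc(/C=C/C#N)cc(C)c1Oc1cc(NCC2CCCO2)nc(Nc2ccc(C#N)cc2)c1`: 73600 nM
- compound 3 `Cc1cc(/C=C/C#N)cc(C)c1Oc1cc(NCCN2CCN(C)CC2)nc(Nc2ccc(C#N)cc2)c1`: 7960 nM

Compound 3 stands lowest of the three, and both gaps to it are beyond the scatter: a 10-fold lower number from compound 1 to compound 3 (1.01 log units; beyond the scatter) and a 9.2-fold lower number from compound 2 to compound 3 (0.97 log units; beyond the scatter). Compound 1 and compound 2 lie within the scatter of each other, a 1.1-fold lower number from compound 1 to compound 2 (0.05 log units; within the scatter).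

Compound 4 `Cc1cc(/C=C/C#N)cc(C)c1Oc1cc(Cl)nc(Nc2ccc(C#N)cc2)c1` is the next step from compound 3: chloro in place of (2-(4-methylpiperazin-1-yl)ethyl)amino on an aromatic carbon. The two steps that bear on it are those adding the (4-methylpiperazin-1-yl)methyl group, each large and each lowering the number in this assay. Among the measured compounds shown here, compound 4 loses that group, so a step the other way is expected, a 7.5-fold higher number from compound 3 to compound 4 (0.88 log units; beyond the scatter), back toward where compound 1 and compound 2 stand, though no measured pair tests chloro itself. Compound 4 is therefore estimated at 60000 nM in this assay, range 15000 nM to 200000 nM.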

Compound 4, half-maximal cytotoxic concentration: > 311000 nM
Compound 4: a limit, no number (the forecaster's own chance of this, stated with the estimate: 20%); middle value at least 5.1-fold (0.71 log units) away from the limit.
By their numbers in this assay, from the lowest: compound 3; then compounds 2 and 1 (each within the scatter of the next). At a limit, above all of these: compound 4.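

In this assay compound 4 gives > 311000 nM, which is a limit and not a number. With chloro on this aromatic carbon in place of each amino group, the steps are an at least 39-fold higher number from compound 3 to compound 4 (1.59 log units; beyond the scatter), an at least 4.2-fold higher number from compound 2 to compound 4 (0.62 log units; beyond the scatter) and an at least 3.7-fold higher number from compound 1 to compound 4 (0.57 log units; beyond the scatter). Compound 4 therefore stands clear not only of compound 3 but also of compound 1 and compound 2, so the position can carry a group with no amino nitrogen and still move the number up.

Going by these compounds, whether this rise belongs to chloro itself or to the loss of the amino chain stays open. A methoxy group or a plain primary amine on this carbon would separate the two.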